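The source may report more compounds than this note shows. Statements on the series, on what has been measured and on what is new or still open speak of the compounds shown alone.

Measured compounds:
compound 1 `O=C(O)Cc1sc(C(c2ccc(F)cc2)c2ccc(F)cc2)nc1-c1cccc(F)c1` — 1.4 nM
compound 2 `O=C(O)Cc1sc(C(c2ccc(F)cc2)c2ccc(F)cc2)nc1-c1ccncc1` — 5.3 nM
compound 3 `O=C(O)Cc1sc(C(c2ccc(F)cc2)c2ccc(F)cc2)nc1-c1cc(F)nc(F)c1` — 5.4 nM

In an in vitro assay on HEK385-7 cells for displacement of a labelled ligand from prostaglandin D2 receptor 2 (Homo sapiens) (a lower number here means a stronger inhibitor, a higher number a weaker inhibitor), compound 3 has the highest of the three numbers. Its nearest neighbour is compound 2, with a 1.0-fold higher number from compound 2 to compound 3 (0.01 log units; within the scatter) separating them; the step from compound 1, a 3.9-fold higher number from compound 1 to compound 3 (0.59 log units; beyond the scatter), is the only one that lies beyond the scatter. Compound 4 `Cc1cc(-c2nc(C(c3ccc(F)cc3)c3ccc(F)cc3)sc2CC(=O)O)cnc1N` is the unmeasured compound; it differs from compound 3 by 6-amino-5-methylpyridin-3-yl in place of 2,6-difluoropyridin-4-yl on an aromatic carbon, the new group sitting on the same aromatic carbon of the five-membered ring, next to the ring nitrogen and next to the ring atom that bears the carboxymethyl group.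

Among the compounds with values here, no measured step replaces one pyridyl group by another carrying an amino and a methyl group. Within the data shown here, the steps that bear on it are indirect: a 3.8-fold higher number from compound 1 to compound 2 (0.58 log units; beyond the scatter) and a 3.9-fold higher number from compound 1 to compound 3 (0.59 log units; beyond the scatter) show that a pyridin-4-yl in place of the 3-fluorophenyl costs a modest amount, and a 1.0-fold higher number from compound 2 to compound 3 (0.01 log units; within the scatter) shows that adding two fluorines to that pyridine changes nothing beyond the scatter. On that basis the writer expects the change to compound 4 to stay close to compound 3, estimated as a 1.1-fold lower number from compound 3 to compound 4 (0.03 log units; within the scatter), with no direction that can be stated beyond the scatter. The estimated value for compound 4 in this assay is 5 nM, expected to lie between 1.5 nM and 20 nM.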

Compound 4, half-maximal inhibitory concentration: 880 nM
The estimate for compound 4 lay 180-fold (2.25 log units) below the measured number; measured number outside the range, above it.
By their numbers in this assay, from the lowest: compound 1; then compounds 2 and 3 (each within the scatter of the next); then compound 4.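

In this assay, the 6-amino-5-methylpyridin-3-yl group shows that this aromatic carbon of the shared core does not accept every pyridine ring alike, with large steps against all three earlier groups: (a 160-fold higher number from compound 3 to compound 4 (2.21 log units; beyond the scatter)), (a 170-fold higher number from compound 2 to compound 4 (2.22 log units; beyond the scatter)) and (a 630-fold higher number from compound 1 to compound 4 (2.80 log units; beyond the scatter)). The earlier exchanges among 3-fluorophenyl, pyridin-4-yl and 2,6-difluoropyridin-4-yl had stayed modest or within the scatter, so a six-membered aromatic ring with one ring nitrogen at this place does not by itself secure a low number, and the group that enters matches the 2,6-difluoropyridin-4-yl group it replaces in heavy atoms. Nothing measured here accounts for the size of these steps.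

The group that enters differs from pyridin-4-yl in three ways at once, the amino group, the methyl group and the ring's point of attachment, and the compounds shown do not separate them. They leave open how a plain pyridin-3-yl, a 6-aminopyridin-3-yl without the methyl or a 5-methylpyridin-3-yl without the amino would stand at this carbon.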